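Changing the Group on the Ring Amine Nitrogen

The source may report more compounds than this note shows. Statements on the series, on what has been measured and on what is new or still open speak of the compounds shown alone.

Compound 1 `Nc1ccccc1NC(=O)c1ccc(CSC(=S)N2CCN(Cc3ccccn3)CC2)cc1` is the stronger of the two measured compounds: in a functional assay on MGC-803 cells (Homo sapiens) for antiproliferative activity, read by CCK-8 assay, with a stated time of 72 h, tested at 2 uM (on this read-out higher numbers stand for a stronger effect at the one concentration tested and lower numbers for a weaker effect), compound 1 gives 23.4%, while compound 2 `Nc1ccccc1NC(=O)c1ccc(CSC(=S)N2CCN(C(c3ccccc3)c3ccccc3)CC2)cc1` gives 9.8% in this assay, a gap beyond the usual scatter. Compound 3 `Nc1ccccc1NC(=O)c1ccc(CSC(=S)N2CCN(c3ncccn3)CC2)cc1` differs from compound 1 in one place: pyrimidin-2-yl in place of (pyridin-2-yl)methyl on an amine nitrogen in a ring. Among the compounds with values here, no measured pair isolates this change, so any expectation rests on compound 1 alone. The expected a number 5.4 percentage points lower from compound 1 to compound 3 (within the scatter) is small, a slight drop at most, staying within the scatter. Compound 3 is therefore estimated at 18%, within a range from 5% to 35%.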

Compound 3, a percentage reported as inhibition, at one concentration (the size of the read-out at that concentration, not a potency): 28.4%
Estimate against measurement, compound 3: 10.4 percentage points below; the range from low to high includes it.
By their numbers in this assay, from the lowest: compound 2; then compounds 1 and 3 (each within the scatter of the next).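

Placing pyrimidin-2-yl in place of (pyridin-2-yl)methyl on this ring amine nitrogen gives a number 5 percentage points higher from compound 1 to compound 3 (within the scatter) in this assay, so the two groups cannot be told apart here. This position therefore holds an aromatic ring with or without the methyl link, at least for this pair. No available evidence explains the result.

The step removes the link and alters the ring at once, so the two changes stay unseparated. As far as these compounds go, a pyridin-2-yl group on this nitrogen, which would separate them, remains open, as does a simple acetyl group.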